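The source may report more compounds than this note shows. Statements on the series, on what has been measured and on what is new or still open speak of the compounds shown alone.

Measured so far in a functional assay on aorta (strain Wistar) for inhibition, with Thoracic aorta (Rattus norvegicus) as the target; a lower number here means a stronger inhibitor, a higher number a weaker inhibitor:

compound 1, `COc1nc(-c2cc3ccccc3o2)cc(-c2ccccc2)c1C#N`, 232000 nM
compound 2, `COc1nc(-c2cc3ccccc3o2)cc(-c2ccc(F)cc2)c1C#N`, 321000 nM
compound 3, `CCOc1nc(-c2cc3ccccc3o2)cc(-c2ccc(F)cc2)c1C#N`, 396000 nM

All three numbers sit in one narrow band. The two single-point steps recorded so far, a 1.4-fold higher number from compound 1 to compound 2 (0.14 log units; within the scatter) and a 1.2-fold higher number from compound 2 to compound 3 (0.09 log units; within the scatter), both stay within the scatter, and the gap between compound 3 and compound 1 is also within it, so compound 3 cannot be set apart from the other two on these data.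

Compound 4, `CCOc1nc(-c2cc3ccccc3o2)cc(-c2cccs2)c1C#N`, awaits measurement. Its change from compound 3 is thiophen-2-yl in place of 4-fluorophenyl on an aromatic carbon. For the measured compounds named here, no measured step exchanges the aryl group at this place for another ring; the only step that touches that group at all is the one from compound 1 to compound 2, which alters a single substituent on it and was within the scatter. Nothing in the series therefore argues for a step beyond the scatter in this assay, in either direction, and the expectation rests on compound 3 alone.

The step that this estimate means, a 1.1-fold lower number from compound 3 to compound 4 (0.05 log units; within the scatter), is expected to lie within the scatter. Compound 4 is thus estimated at 350000 nM, with a range from 130000 nM to 950000 nM.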

Compound 4, half-maximal inhibitory concentration: 308000 nM
Beside the measured number, compound 4's estimate is 1.1-fold (0.06 log units) above it; the range from low to high includes it.
By their numbers in this assay, from the lowest: compounds 1, 4, 2 and 3 (each within the scatter of the next).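

In this assay, for the compounds shown here, thiophen-2-yl in place of 4-fluorophenyl on the aromatic carbon opposite the ring nitrogen gives a 1.3-fold lower number from compound 3 to compound 4 (0.11 log units; within the scatter), the first step to exchange the whole ring at this place rather than alter a single substituent on it. Going by these compounds alone, a five-membered aromatic ring with one sulfur atom therefore cannot be told apart from the fluorinated six-membered carbon ring at this position on these data, and compound 4, at 308000 nM, stays in the same narrow band as the earlier compounds. No independent measurement is available to explain this result.

With every step so far within the scatter, the compounds shown do not reveal whether any change at this position can move the number beyond it, for example an aryl ring bearing an amine or a carboxylic acid, or a saturated ring in place of the aryl group. Also open are the effects of a chain longer than ethoxy and of replacing the cyano or 1-benzofuran-2-yl group, since no step shown touches either of these two groups.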